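Swapping methyl for chloro on a weakly active scaffold

This account rests on a few compounds, and the source may have more. Where it says the series, first, only, none or still open, it means among the compounds named here.

Compound 2 `COC(=O)[C@@]1(C)CC[C@@H]2C3=C1CC[C@@H](C)[C@]3(C)C[C@@H]1c3cc(C)ccc3N[C@H]21` was tested in a functional assay on HBL-100 cells (Homo sapiens) for inhibition, read by sulforhodamine B assay, with a stated time of 48 h (on this read-out higher numbers stand for weaker inhibition of growth and lower numbers for stronger inhibition of growth), where compound 2 gives 15000 nM. Compound 1 `COC(=O)[C@@]1(C)CCC=C2[C@@H]1CC[C@@H](C)[C@]2(C)Cc1c[nH]c2ccc(C)cc12` in this assay gives 18000 nM; the two numbers lie within the scatter of each other, so neither can be called stronger. Compound 3 `COC(=O)[C@@]1(C)CC[C@@H]2C3=C1CC[C@@H](C)[C@]3(C)C[C@@H]1c3cc(Cl)ccc3N[C@H]21` differs from compound 2 by chloro in place of methyl on an aromatic carbon. Among the compounds with values here, no measured pair shows what such a swap does here, so the step of a 1.3-fold lower number from compound 2 to compound 3 (0.10 log units; within the scatter) is expected to stay within the scatter, in no clear direction. Compound 3 is therefore estimated at 12000 nM, with a range from 5000 nM to 35000 nM.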

Compound 3, concentration for 50% growth inhibition: 28000 nM
Compound 3: the middle estimate sits 2.3-fold (0.37 log units) below what was measured, and the stated range covers the measured number.
By their numbers in this assay, from the lowest: compounds 2, 1 and 3 (each within the scatter of the next).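

Within the data shown here, on this aromatic carbon, chloro in place of methyl gives a 1.9-fold higher number from compound 2 to compound 3 (0.27 log units; within the scatter) in this assay and is the first direct reading of this swap on the shared core. Both groups leave growth inhibition weak, and the step cannot be told from the scatter, so neither group can be ranked above the other at this position. Nothing measured here offers an explanation for these numbers. As far as these compounds go, whether an amine or a carboxylic acid on this carbon would shift the number beyond the scatter remains open.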